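Chloro in Place of Fluoro, Estimating Compound 4

The source may report more compounds than this note shows. Statements on the series, on what has been measured and on what is new or still open speak of the compounds shown alone.

Compound 1 `N#CC1=C(N)Oc2c(c3nc4ccccc4nc3c3ccccc23)C12C(=O)N(Cc1cnnn1-c1ccc(F)cc1)c1ccccc12`: in a functional assay on HCT-116 cells (Homo sapiens) for antiproliferative activity, read by MTT assay, with a stated time of 48 h (on this read-out lower numbers stand for stronger inhibition and higher numbers for weaker inhibition), compound 1 gives > 50000 nM, which is a limit of the assay and not a number.
Compound 2 `N#CC1=C(N)Oc2c(c3nc4ccccc4nc3c3ccccc23)C12C(=O)N(Cc1cnnn1-c1ccc(Cl)cc1)c1ccccc12`: in this assay compound 2 gives > 50000 nM, again a limit of the assay.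
Compound 3 `N#CC1=C(N)Oc2c(N)cc3nc4ccccc4nc3c2C12C(=O)N(Cc1cnnn1-c1ccc(F)cc1)c1ccccc12`: in this assay compound 3 gives > 50000 nM, also a limit of the assay.

The change from compound 1 to compound 2 is chloro in place of fluoro on an aromatic carbon. Its size in this assay is a step that the two limits leave unreadable from compound 1 to compound 2, because of the limit of > 50000 nM in this assay, at which 3 of the 3 values shown sit; both ends of the step sit at the limit, so nothing about its direction or size can be read.

Compound 4 `N#CC1=C(N)Oc2c(N)cc3nc4ccccc4nc3c2C12C(=O)N(Cc1cnnn1-c1ccc(Cl)cc1)c1ccccc12` has not yet been measured. It differs from compound 3 by chloro in place of fluoro on an aromatic carbon. The place of this change reads word for word the same as for the change from compound 1 to compound 2, so the two are the same change, carried out on a different core. How the core of compound 3 differs from the core of compound 1 is not broken down here.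

From compound 3 to compound 4 the expected step in this assay is a step that the limit leaves unreadable from compound 3 to compound 4, which rests on the unreadable step that the two limits leave unreadable from compound 1 to compound 2 and on the fact that compound 3 gives > 50000 nM, a limit. With every shown value at the limit, compound 4 is expected to give 80000 nM, within a range from 30000 nM to 300000 nM, and most likely the assay will again report only a limit.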

Compound 4, half-maximal inhibitory concentration: > 50000 nM
Compound 4: a limit, no number; the forecaster's own chance of this, stated with the estimate: 85%; the middle value lies beyond the limit too.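

In this assay compound 4 gives > 50000 nM, which is a limit of the assay and not a number. Among the compounds shown here, the step from compound 3 to compound 4 therefore cannot be read, any more than the one from compound 1 to compound 2, because both ends of each step sit at the same limit: the limit of > 50000 nM in this assay, at which 4 of the 4 values shown sit. The compounds shown leave open whether 4-chlorophenyl in place of 4-fluorophenyl makes any difference in this assay, on either core.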